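Tetrazole to carboxylic acid on the alkoxy chain

The source may hold more compounds than are shown below. What is called first, only, known or untested is meant among the compounds shown, and "the series" means these compounds.

Measured compounds:
Compound 1 `CCc1cc(C(C)=O)c(O)cc1OCCCCC(C)(C)C#N`: 30%
Compound 2 `CCc1cc(C(C)=O)c(O)cc1OCCCCCC(C)(C)C#N`: 53%
Compound 3 `CCc1cc(C(C)=O)c(O)cc1OCCCC(C)(C)c1nnn[nH]1`: 76%

In an assay on isolated protein for binding affinity to leukotriene B4 receptor 1 (Homo sapiens), tested at 1 uM (a higher number here means more inhibition at the concentration tested (going by the name of the read-out), a lower number less inhibition), compound 3 stands highest of the three, with compound 2 nearest (a number 23 percentage points higher from compound 2 to compound 3 (beyond the scatter)) and compound 1 furthest (a number 46 percentage points higher from compound 1 to compound 3 (beyond the scatter)). Compound 4 `CCc1cc(C(C)=O)c(O)cc1OCCCCCCC(=O)O` is not yet measured. It differs from compound 3 as follows: 3-carboxypropyl in place of 1-(1H-tetrazol-5-yl)-1-methylethyl on a saturated chain carbon, three bonds along the chain from an oxygen on an aromatic ring. For the measured compounds named here, no measured step covers this exchange; the known steps, a number 23 percentage points higher from compound 1 to compound 2 (beyond the scatter) and the two above, only show that the tetrazole-bearing compound 3 outran both nitrile-bearing compounds. Both groups exchanged carry one hydrogen-bond donor, so the step is expected to be small, a number 11 percentage points lower from compound 3 to compound 4 (beyond the scatter), with wide uncertainty. Compound 4 is therefore estimated at 65%, in the range 40% to 88%.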

Compound 4, a percentage reported as inhibition, at one concentration (the size of the read-out at that concentration, not a potency): 38%
Compound 4: the middle estimate sits 27 percentage points above what was measured; the measured number lies below the stated range.
By their numbers in this assay, from the lowest: compounds 1 and 4 (each within the scatter of the next); then compound 2; then compound 3.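

In this assay, the exchange of 1-(1H-tetrazol-5-yl)-1-methylethyl for 3-carboxypropyl gives a number 38 percentage points lower from compound 3 to compound 4 (beyond the scatter), so the shared count of one hydrogen-bond donor does not make the two groups interchangeable at this place. Against the nitrile-bearing compounds, the carboxylic acid chain gives a number 15 percentage points lower from compound 2 to compound 4 (beyond the scatter), and a number 8 percentage points higher from compound 1 to compound 4 (within the scatter), so the lead held by compound 3 is not kept. Nothing available bears on the reason for this result.

Still open, from the compounds shown here alone, is whether the drop follows the acid group or the loss of the branched chain carbon. A carboxylic acid on the branched 1-methylethyl chain, or a tetrazole on the straight chain, would separate the two.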